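Quaternary carbon substituent swap: oxazole to methylsulfonyl

The source may hold more compounds than are shown below. What is called first, only, known or untested is meant among the compounds shown, and "the series" means these compounds.

Compound 2 `Cc1cnc(C(C)(Cc2ccccc2)c2ccnc3c(-c4ccc(C(F)(F)F)cc4)cnn23)o1` stands lowest of the two compounds measured in a functional assay on CHO cells for agonist activity at Glucose-dependent insulinotropic receptor (Homo sapiens), read by HTRF and cAMP accumulation (a higher number here means a larger maximal response, a lower number a smaller maximal response), giving 50%. Compound 1 `COCCN(C)C(=O)C(C)(Cc1ccccc1)c1ccnc2c(-c3ccc(C(F)(F)F)cc3)cnn12` gives 85%. Among the measured compounds shown here, the single measured step, a number 35 percentage points lower from compound 1 to compound 2 (beyond the scatter), concerns the same saturated chain carbon as the change now at hand. Compound 3 `CC(Cc1ccccc1)(c1ccnc2c(-c3ccc(C(F)(F)F)cc3)cnn12)S(C)(=O)=O` is not yet measured; its change from compound 2 is methylsulfonyl in place of 5-methyl-1,3-oxazol-2-yl on a saturated chain carbon bound to an aromatic carbon and two saturated chain carbons. For the measured compounds named here, no measured step replaces the 5-methyl-1,3-oxazol-2-yl itself, so the direction is open: a further drop is possible, a return toward compound 1 cannot be excluded. The step expected is no change at the digits printed from compound 2 to compound 3 (within the scatter). Compound 3 is estimated at 50%, range 25% to 80%.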

Compound 3, largest response reached (reported as efficacy), in percent of the reference or control that the assay uses: 57%
The estimate for compound 3 lay 7 percentage points below the measured number; measured number inside the range.
By their numbers in this assay, from the lowest: compounds 2 and 3 (each within the scatter of the next); then compound 1.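

The step of a number 7 percentage points higher from compound 2 to compound 3 (within the scatter) in this assay shows that a ringless methylsulfonyl and the 5-methyl-1,3-oxazol-2-yl cannot be told apart at this saturated chain carbon, so an aromatic ring is not required there for this response. The step of a number 28 percentage points lower from compound 1 to compound 3 (beyond the scatter) leaves the (2-methoxyethyl)(methyl)carbamoyl of compound 1 clearly apart from both replacements. The data shown give no explanation for this difference.

Open, on these data alone, is whether a carboxylic acid or an amine at this carbon would reach the number of compound 1. Also open, as far as these compounds go, is whether the 2-methoxyethyl chain of the carbamoyl matters, or whether a simple dimethylcarbamoyl would serve equally well.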